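The compounds below may be only part of what the source reports. "The series", "measured", "known", "first", "only" and "open" are said of these compounds alone.

In an ADME assay on CHO cells (Cricetulus griseus) for inhibition, read by MTT assay (a higher number here means a weaker inhibitor, a lower number a stronger inhibitor), compound 1 (`CC(C)(C)NCc1cc(Cl)cc(Nc2nc3cc(F)c(F)cc3n2Cc2ccc(C(F)(F)F)cc2)c1O`) reads > 50000 nM as a limit of the assay and not a number. Compound 2 (`Cc1cc(CNC(C)(C)C)c(O)c(Nc2nc3cc(F)c(F)cc3n2Cc2ccc(C(F)(F)F)cc2)c1`), with methyl in place of chloro on an aromatic carbon, gives 10000 nM as a measured number. Among the compounds with values here, the only measured step is an at least 5.0-fold lower number from compound 1 to compound 2 (0.69 log units; beyond the scatter) and it concerns that aromatic carbon, not the amine. Compound 3 (`CCNCc1cc(Cl)cc(Nc2nc3cc(F)c(F)cc3n2Cc2ccc(C(F)(F)F)cc2)c1O`) keeps the chloro group of compound 1 and carries ethyl in place of tert-butyl on an amine nitrogen and it still awaits measurement. Within the data shown here, no measured step touches that amine nitrogen, so the size of the change can be judged only loosely. Taking an at least 5.0-fold lower number from compound 1 to compound 2 (0.69 log units; beyond the scatter) as the sole guide to what one change can do here, a modest move toward a lower number is expected, although a second reading as a limit is also quite possible. The expected change is an at least 1.4-fold lower number from compound 1 to compound 3 (0.15 log units; that floor lies within the scatter) as a rough estimate. For compound 3 the estimated value is 35000 nM with an expected range between 10000 nM and 100000 nM for that estimate.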

Compound 3, half-maximal inhibitory concentration: > 50000 nM
Compound 3 was reported as a limit; the forecaster's own chance of this, stated with the estimate: 45%; at least 1.4-fold (0.15 log units) between middle value and limit.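

In this assay compound 3 gives > 50000 nM, a limit of the assay and not a number. Compound 1 is also reported as a limit, so no step from compound 1 to compound 3 can be read: the limit of > 50000 nM in this assay, at which 2 of the 3 values shown sit. The compounds shown leave open how ethyl and tert-butyl on the amine nitrogen compare in this assay.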